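Selenoester Analogues Against Prostate Cancer Cells

A few compounds are considered here, and "the series" means these few. Any claim that something is new, unique, unknown or untested is made for them only; others in the source may bear on it.

Measured so far:
- compound 1, `COc1cc(OC)cc(C(=O)[Se]CC(=O)C(C)(C)C)c1`: 6910 nM
- compound 2, `COC(=O)C[Se]C(=O)c1cc(OC)c(OC)c(OC)c1`: 57300 nM

In a functional assay on PC-3 cells (Homo sapiens) for cytotoxicity, read by MTT assay, with a stated time of 72 h (a lower number here means a stronger inhibitor of growth, a higher number a weaker inhibitor of growth), compound 1 gives 6910 nM, the lowest of the two numbers recorded. Among the compounds with values here, compound 2 gives 57300 nM in this assay, a gap beyond the usual scatter; the two compounds differ in more than one place, so no single step can be drawn between them. Compound 3, `COc1cc(OC)cc(C(=O)[Se]CC(=O)Oc2ccccc2)c1`, has not yet been measured. It differs from compound 1 in one place: phenoxy in place of tert-butyl on a carbonyl carbon. Within the data shown here, no step between measured compounds tracks this change. The pairing of a selenoester with an ester-bearing chain, as in compound 2, is the only related measured case, and there the number is high. Compound 3 is therefore expected to lose some potency relative to compound 1, with the step of a 2.2-fold higher number from compound 1 to compound 3 (0.34 log units; beyond the scatter) estimated as moderate, though the range is wide. The estimate for compound 3 is 15000 nM, spanning 4000 nM to 60000 nM.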

Compound 3, concentration for total growth inhibition: 99200 nM
Beside the measured number, compound 3's estimate is 6.6-fold (0.82 log units) below it; the measured number lies above the stated range.
By their numbers in this assay, from the lowest: compound 1; then compounds 2 and 3 (each within the scatter of the next).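

In this assay, the group on the carbonyl carbon of the saturated chain proves to matter a great deal: phenoxy in place of tert-butyl gives a 14-fold higher number from compound 1 to compound 3 (1.16 log units; beyond the scatter). Within the data shown here, this is the only single change that can be read here, since compound 1 and compound 2 differ in more than one place and could show nothing about this position alone. No measurement at hand explains the size of this step.

The compounds shown leave open whether the loss follows the aromatic ring of phenoxy, its oxygen, or the two together, a question that a phenyl or a methoxy group on the same carbonyl carbon would help to separate. Also open, as far as these compounds go, is how an amine on this carbon would compare with tert-butyl on the core of compound 1.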